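The compounds below may be only part of what the source reports. "The series", "measured", "known", "first", "only" and "open" are said of these compounds alone.

In an ADME assay on HEK293 cells (Homo sapiens) for cytotoxicity, read by ATP content, with a stated time of 6 h (a higher number here means that more compound is tolerated, a lower number that less compound is tolerated), compound 1 (`CCCCNc1nc(N)nc2ccn(Cc3nccs3)c12`) gives > 24000 nM as a limit of the assay. Compound 2 (`CCCCNc1nc(N)nc2ccn(Cc3ccccn3)c12`) gives > 24000 nM, again a limit and not a number. Compound 3 (`CCCCNc1nc(N)nc2ccn(Cc3ccncc3)c12`) gives > 24000 nM, which is likewise a limit. All three compounds stand at the limit of > 24000 nM in this assay, at which 3 of the 3 values shown sit, and none of them reads otherwise, so compound 3 has no measured number of its own.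

Compound 4 (`CCCCNc1nc(N)nc2ccn(Cc3cccc(C)n3)c12`) carries 6-methylpyridin-2-yl in place of pyridin-4-yl on a saturated chain carbon bound to an aromatic nitrogen. The measured swaps at that same place are the ones that bear on this change. The closest is a step that the two limits leave unreadable from compound 2 to compound 3 and the other two are a step that the two limits leave unreadable from compound 1 to compound 2 and a step that the two limits leave unreadable from compound 1 to compound 3 (none of them has a readable size). For the measured compounds named here, with no step of known size to carry over, no change beyond the scatter is expected in this assay and no direction can be given. The estimate means a number no higher from compound 3 to compound 4 (the limit leaves the size open) as the expected step. Compound 4 is estimated at 24000 nM (expected range 14000 nM to 40000 nM), and most likely this assay will again report only a limit.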

Compound 4, half-maximal cytotoxic concentration: > 24000 nM
Compound 4 gave a limit, no number; the forecaster's own chance of this, stated with the estimate: 85%; the middle value lies on the limit itself.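

In this assay compound 4 gives > 24000 nM, again a limit and not a number, so no step linking it with compound 1, compound 2 or compound 3 can be read: the limit of > 24000 nM in this assay, at which 4 of the 4 values shown sit.

The compounds shown leave open how much of each is tolerated in this assay, and whether 1,3-thiazol-2-yl, pyridin-2-yl, pyridin-4-yl and 6-methylpyridin-2-yl differ there at all.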